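The compounds below may be only part of what the source reports. "The series", "measured", "known", "first", "only" and "open" are said of these compounds alone.

Among the compounds with values here, in a functional assay on HepG2 cells (Homo sapiens) for antiproliferative activity, read by MTT assay, with a stated time of 48 h (on this read-out lower numbers stand for stronger inhibition of growth and higher numbers for weaker inhibition of growth), compound 1 (`CCCCCN(Cc1ccc(C(=O)NO)cc1)c1ncc(-c2ccc(C)cc2)s1`) gives 7020 nM and compound 2 (`CCCCCCCCN(Cc1ccc(C(=O)NO)cc1)c1ncc(-c2ccc(C)cc2)s1`) gives 8760 nM, so compound 2 stands level with the only other measured compound. Compound 3 (`Cc1ccc(-c2cnc(N(CCCCOc3ccccc3)Cc3ccc(C(=O)NO)cc3)s2)cc1`) has phenoxy in place of butyl on a saturated chain carbon, four bonds along the chain from a nitrogen on an aromatic ring. Within the data shown here, the one measured guide is a change of the chain alone, a 1.2-fold higher number from compound 1 to compound 2 (0.10 log units; within the scatter), and no measured step involves a ring on that chain. No change beyond the scatter is therefore expected in this assay. The expected move is a 1.3-fold lower number from compound 2 to compound 3 (0.10 log units; within the scatter). Compound 3 is estimated at 7000 nM, with an expected range from 2800 nM to 16000 nM.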

Compound 3, concentration for 50% growth inhibition: 16600 nM
Compound 3: middle estimate off by 2.4-fold (0.38 log units), on the low side; the whole stated range lies below it.
By their numbers in this assay, from the lowest: compounds 1, 2 and 3 (each within the scatter of the next, the first and the last beyond it).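

In this assay, within the data shown here, phenoxy on the chain gives a 1.9-fold higher number from compound 2 to compound 3 (0.28 log units; within the scatter), which stays within the scatter, whereas a 2.4-fold higher number from compound 1 to compound 3 (0.37 log units; beyond the scatter) is the first step to pass it, a modest weakening of growth inhibition. A ring-bearing chain at this place therefore shows no gain over the plain alkyl chains, and the set's only clear difference separates it from the shorter one. No evidence given here explains this difference. Still open, on these data alone, is how an amine or a carboxylic acid would read in place of phenoxy, and whether a longer chain carrying phenoxy would read differently.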